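A fluoro added to inactive compound 2

The source may hold more compounds than are shown below. What is called first, only, known or untested is meant among the compounds shown, and "the series" means these compounds.

In a functional assay on HeLa cells (Homo sapiens) for inhibition, read by MTT assay, with a stated time of 48 h (a lower number here means a stronger inhibitor, a higher number a weaker inhibitor), compound 1 `O=C(CC(c1ccc(F)cc1)C(C(=O)Nc1ccccn1)C(=O)Nc1ccccn1)c1ccccc1` gives 20800 nM as its reading, while compound 2 `O=C(CC(c1ccccc1)C(C(=O)Nc1ccccn1)C(=O)Nc1ccccn1)c1ccc(F)cc1` is recorded as "not active" (no number reported) and so has no number to stand on. Compound 3 `O=C(CC(c1ccc(F)cc1)C(C(=O)Nc1ccccn1)C(=O)Nc1ccccn1)c1ccc(F)cc1` has not yet been measured. It differs from compound 2 in one place. That change fluoro in place of hydrogen on an aromatic carbon is fluoro in place of hydrogen on an aromatic carbon, phenyl to 4-fluorophenyl. In this assay a step toward weak but measurable inhibition is expected, its size open, since compound 1 at 20800 nM holds the same 4-fluorophenyl group. For compound 3 an estimated 30000 nM is expected, within 10000 nM to 90000 nM as the range.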

Compound 3, half-maximal inhibitory concentration: 25500 nM
Estimate against measurement, compound 3: 1.2-fold (0.07 log units) above; measured number inside the range.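

In this assay, 4-fluorophenyl at this position gives compound 3 a measurable reading, whereas compound 2, with phenyl there, has no number, so that step cannot be read. With 4-fluorophenyl already present on one side, fluoro in place of hydrogen on the other aromatic ring gives a 1.2-fold higher number from compound 1 to compound 3 (0.09 log units; within the scatter), so compound 3 reads alike with compound 1. Nothing measured here explains either observation. Going by these compounds, whether a chloro, a methoxy or an amine in place of either fluoro would give a lower number remains open.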